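Formyl shift on the thiophene: compound 2 to compound 3

A few compounds are considered here, and "the series" means these few. Any claim that something is new, unique, unknown or untested is made for them only; others in the source may bear on it.

Within the data shown here, in a functional assay on MV4-11 cells (Homo sapiens) for inhibition, read by resazurin assay, with a stated time of 72 h (a higher number here means a weaker inhibitor of growth, a lower number a stronger inhibitor of growth), compound 2 `O=Cc1sccc1-c1cncc(Cl)c1N1CCC2(CCNC2=O)CC1` stands at 28700 nM as the higher of the two numbers so far, against compound 1 `O=C1NCCC12CCN(c1c(Cl)cncc1-c1ccsc1)CC2` at 190 nM with a gap beyond the scatter. Compound 3 `O=Cc1cc(-c2cncc(Cl)c2N2CCC3(CCNC3=O)CC2)cs1` has the same atoms as compound 2 joined differently, with 5-formylthiophen-3-yl in place of 2-formylthiophen-3-yl on an aromatic carbon. Among the measured compounds shown here, the one measured step that bears on this, a large one beyond the scatter, is a 150-fold higher number from compound 1 to compound 2 (2.18 log units; beyond the scatter) for formyl in place of hydrogen on an aromatic carbon. For the measured compounds named here, no measured compound carries the formyl at the new place, so this step guides only loosely. A lower number is expected in this assay with part of that step undone, not all of it. The expected step is a 9.6-fold lower number from compound 2 to compound 3 (0.98 log units; beyond the scatter) on this estimate. For compound 3 the estimated value is 3000 nM (expected range 500 nM to 15000 nM).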

Compound 3, concentration for 50% growth inhibition: 730 nM
Compound 3: the middle estimate sits 4.1-fold (0.61 log units) above what was measured; measured number inside the range.
By their numbers in this assay, from the lowest: compound 1; then compound 3; then compound 2.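

In this assay the effect of the formyl group depends strongly on where it sits on the thiophene: the two isomers carry the same atoms, yet 5-formylthiophen-3-yl in place of 2-formylthiophen-3-yl gives a 39-fold lower number from compound 2 to compound 3 (1.59 log units; beyond the scatter) and recovers most of the earlier loss. What remains is a 3.8-fold higher number from compound 1 to compound 3 (0.58 log units; beyond the scatter) for the added formyl, set against a 150-fold higher number from compound 1 to compound 2 (2.18 log units; beyond the scatter) at the other place, so the group is far better tolerated at the new place, though not fully. Nothing on hand accounts for the difference between the two placements.

Still open, as far as these compounds go, is whether the remaining loss belongs to the formyl itself or to any group at that place. A hydroxymethyl, an aminomethyl or a carboxylic acid in place of the formyl of compound 3 would bear on this.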